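Sulfone to sulfonamide on the aryl sulfonyl tail

The compounds below may be only part of what the source reports. "The series", "measured", "known", "first", "only" and "open" are said of these compounds alone.

The series is read in a functional assay on MIA PaCa-2 cells (Homo sapiens) for inhibition, read by MTT assay, with a stated time of 3 days; on this read-out higher numbers stand for weaker inhibition and lower numbers for stronger inhibition. Compound 1 `CCOC(=O)[C@@H]1C[C@@H](O)CN(S(=O)(=O)c2ccc(S(=O)(=O)N(CC)CC)cc2)C1` gives 2100 nM. Compound 3 `CCOC(=O)[C@@H]1CCCN(S(=O)(=O)c2ccc(S(=N)(=O)N(CC)CC)cc2)C1` gives 900 nM. Compound 2 `CC(C)c1noc(N2CCN(C(=O)[C@@H]3CCCN(S(=O)(=O)c4ccc(S(=O)(=O)C5CCC5)cc4)C3)CC2)n1` gives 20 nM, the lowest number of the three; compound 3 is nearest and compound 1 furthest, and both gaps lie beyond the scatter. Compound 4 `CC(C)c1noc(N2CCN(C(=O)[C@@H]3CCCN(S(=O)(=O)c4ccc(S(=O)(=O)NC5CCC5)cc4)C3)CC2)n1` differs from compound 2 in one place: cyclobutylamino in place of cyclobutyl on a sulfonyl sulfur. Among the compounds with values here, no measured pair differs in just this way, so the step has no measured precedent, and compounds 1 and 3 do not isolate it. The expected step, a 1.8-fold higher number from compound 2 to compound 4 (0.24 log units; within the scatter), is small and possibly within the scatter. Compound 4 is estimated at 35 nM, with a range from 10 nM to 120 nM.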

Compound 4, half-maximal inhibitory concentration: 200 nM
For compound 4 the middle estimate is 5.7-fold (0.76 log units) below the measured one; the measured number lies above the stated range.
By their numbers in this assay, from the lowest: compound 2; then compound 4; then compound 3; then compound 1.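

Within the data shown here, this position on the sulfonyl sulfur is sensitive in this assay: cyclobutylamino in place of cyclobutyl gives a 10-fold higher number from compound 2 to compound 4 (1.00 log units; beyond the scatter), the first one-place step. The change enters one nitrogen and one hydrogen-bond donor, and this single step cannot separate the two. Nothing measured on these compounds accounts for the step.

Open, on these data alone, is whether N-methylcyclobutylamino, which keeps the nitrogen but carries no hydrogen on it, stays closer to compound 2. Also open, as far as these compounds go, is how cyclopentyl or isopropyl on the same sulfur would read.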